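Hydroxymethyl in place of ethoxycarbonyl on the piperazine-type core

The compounds below may be only part of what the source reports. "The series", "measured", "known", "first", "only" and "open" are said of these compounds alone.

Of the compounds shown here, three have been measured in a functional assay on the whole organism (strain CD-1) with Mus musculus as the target, with a stated time of 20 min; on this read-out higher numbers stand for an effect only at larger amounts of compound and lower numbers for an effect already at smaller amounts. Among the measured compounds shown here, compound 1 `CC(=O)OC[C@H]1CN(C(C)=O)CCN1S(=O)(=O)c1ccc(F)cc1` gives 1 mg/kg, and compound 2 `CC(=O)OC[C@@H]1CN(C(C)=O)CCN1S(=O)(=O)c1ccc(F)cc1` gives 1 mg/kg; the step of no change at the digits printed from compound 1 to compound 2 (within the scatter) is the only one-point step among them, and because of the fact that compounds 1 and 2 differ only in the configuration as drawn it speaks only to configuration. Compound 3 `CCOC(=O)C1CN(C(C)=O)CCN1S(=O)(=O)c1ccc(F)cc1` gives 0.1 mg/kg, the lowest number of the three, and its difference from each of compound 1 and compound 2 lies beyond the scatter.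

Compound 4 `CC(=O)N1CCN(S(=O)(=O)c2ccc(F)cc2)C(CO)C1` differs from compound 3 by hydroxymethyl in place of ethoxycarbonyl on a saturated ring carbon. For the measured compounds named here, no measured step covers this kind of exchange, so the expectation rests on the spread of the series: compound 3 marks its low end with 0.1 mg/kg, while compound 1 marks its high end with 1 mg/kg and compound 2 does so with 1 mg/kg. Compound 4 is expected to move upward from compound 3 by a 5.0-fold higher number from compound 3 to compound 4 (0.70 log units; beyond the scatter), landing between the two ends. The estimate for compound 4 in this assay is 0.5 mg/kg, with a range from 0.1 mg/kg to 3 mg/kg.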

Compound 4, minimum effective dose: 1 mg/kg
Compound 4: the middle estimate sits 2.0-fold (0.30 log units) below what was measured; measured number inside the range.
By their numbers in this assay, from the lowest: compound 3; then compounds 1, 2 and 4 (each within the scatter of the next).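

In this assay, the exchange at this saturated ring carbon gives a 10-fold higher number from compound 3 to compound 4 (1.00 log units; beyond the scatter), so the number here responds to the group the position carries, whereas the earlier one-point step spoke only to configuration. Ethoxycarbonyl has no hydrogen-bond donor and hydroxymethyl has one, but this single step cannot separate that difference from the change in the number of heavy atoms. Nothing measured in this series gives a reason for the step.

Going by these compounds, what remains open is which part of ethoxycarbonyl matters, a question that a carboxylic acid, a methoxycarbonyl group or a primary amide on the same ring carbon could address. On these data alone, it is also open whether configuration at this carbon matters with ethoxycarbonyl or hydroxymethyl, as compound 3 and compound 4 are drawn without it.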